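The compounds below may be only part of what the source reports. "The series", "measured", "known", "first", "only" and "open" are said of these compounds alone.

Measured compounds, each with its value in a functional assay on HeLa cells (Homo sapiens) for antiproliferative activity, read by MTT assay, with a stated time of 48 h; on this read-out higher numbers stand for weaker inhibition and lower numbers for stronger inhibition:

Compound 1 `CCNc1ccc2ncc(-c3cnn(C)c3)cc2n1` gives > 50000 nM, a limit of the assay.
Compound 2 `Cn1cc(-c2cnc3ccc(NCC4CC4)nc3c2)cn1` gives > 50000 nM, likewise a limit.
Compound 3 `CCNc1nccc2ncc(-c3cnn(C)c3)cc12` gives > 50000 nM, again a limit.

All three measured compounds sit at the limit of > 50000 nM in this assay, at which 3 of the 3 values shown sit, so none of them yields a number in this assay. Compound 1 and compound 3 are built from the same atoms joined differently; the difference between the two cores is not broken down here. Compound 2 is derived from compound 1 by one change, (cyclopropyl in place of methyl on a saturated chain carbon bound to a nitrogen on an aromatic ring), and the step it made, a step that the two limits leave unreadable from compound 1 to compound 2, cannot be read because both ends are limits.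

Compound 4 `Cn1cc(-c2cnc3ccnc(NCC4CC4)c3c2)cn1` has not yet been measured in this assay. It is derived from compound 3 by the same change, (cyclopropyl in place of methyl on a saturated chain carbon bound to a nitrogen on an aromatic ring), on the core of compound 3 rather than that of compound 1.

Going by the values given here, since the only earlier instance of this change, from compound 1 to compound 2, moved between two limits, and compound 3 itself stands at a limit, the step from compound 3 to compound 4 is expected to be unreadable in the same way, a step that the limit leaves unreadable from compound 3 to compound 4. Compound 4 is therefore estimated at 80000 nM in this assay, most likely reported as a limit once more, with the expected range running from 30000 nM to 300000 nM.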

Compound 4, half-maximal inhibitory concentration: 7400 nM
For compound 4 the middle estimate is 11-fold (1.03 log units) above the measured one; the whole stated range lies above it.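

In this assay, putting cyclopropyl in place of methyl on a saturated chain carbon bound to a nitrogen on an aromatic ring gives an at least 6.7-fold lower number from compound 3 to compound 4 (0.82 log units; beyond the scatter), which shows that this change can produce a readable result on this core. The same change on the core of compound 1 joins two limits, and its step cannot be read, so the series offers one readable instance of the change and no second one to compare it with; the data neither show that the result carries from one core to the other nor show that it fails to carry. The true size of the readable step also stays unknown, since its starting point is a limit and not a number, and that limit is shared by most of the series: the limit of > 50000 nM in this assay, at which 3 of the 4 values shown sit.

The compounds shown leave open whether a longer chain such as n-propyl or n-butyl, or a benzyl group, in place of cyclopropylmethyl would give a lower number than compound 4 does on the same core. They also leave open whether cyclobutylmethyl would behave as cyclopropylmethyl does, and whether any such group would lift the core of compound 1 off its limit.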